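Cytotoxicity of bis-aryloxyethylamines: varying the benzyl group

The source may report more compounds than this note shows. Statements on the series, on what has been measured and on what is new or still open speak of the compounds shown alone.

Measured compounds:
Compound 1, `COc1cccc(OC)c1OCCNCCOc1ccccc1OCc1cccc(Cl)c1`: 58900 nM
Compound 2, `COc1cccc(OC)c1OCCNCCOc1ccccc1OCc1ccc(Cl)cc1`: 52500 nM

The two measured compounds share one core and differ only in the group carried on a saturated chain carbon bound to an oxygen on an aromatic ring. In a functional assay on PC-3 cells (Homo sapiens) for cytotoxicity, read by sulforhodamine B assay (a higher number here means that more compound is tolerated, a lower number that less compound is tolerated), compound 1 gives 58900 nM, the highest of the two numbers shown, and compound 2 gives 52500 nM. The step of a 1.1-fold lower number from compound 1 to compound 2 (0.05 log units; within the scatter) is within the scatter, so the two compounds cannot be ordered on these data.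

Compound 3, `COc1cccc(OC)c1OCCNCCOc1ccccc1OCc1ccc(OC(C)C)cc1`, has not yet been measured in this assay. It differs from compound 1 in one place:
4-isopropoxyphenyl in place of 3-chlorophenyl on a saturated chain carbon bound to an oxygen on an aromatic ring
For the measured compounds named here, the only measured step bearing on this change is a 1.1-fold lower number from compound 1 to compound 2 (0.05 log units; within the scatter), which concerns the same position but exchanges one chlorophenyl for another, and it was within the scatter. Going by the values given here, no measured step shows what an isopropoxy group does at this position. Compound 3 is therefore expected to stay close to compound 1, with a step of a 1.1-fold lower number from compound 1 to compound 3 (0.03 log units; within the scatter) not expected to exceed the scatter. The estimate for compound 3 in this assay is 55000 nM, within a range of 22000 nM to 130000 nM.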

Compound 3, concentration lethal to 50% of the cells: 63100 nM
Beside the measured number, compound 3's estimate is 1.1-fold (0.06 log units) below it, within the range that was stated.
By their numbers in this assay, from the lowest: compounds 2, 1 and 3 (each within the scatter of the next).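

Until this point the position had been probed only with two chlorophenyl groups, and compound 3 shows that the chlorine can give way altogether to an isopropoxy group with no readable effect: this assay records a 1.1-fold higher number from compound 1 to compound 3 (0.03 log units; within the scatter) and, with the same substituent exchanged on the other chlorinated compound, a 1.2-fold higher number from compound 2 to compound 3 (0.08 log units; within the scatter) for isopropoxy in place of chloro on an aromatic carbon. Across compounds 1, 2 and 3, then, the 3-chlorobenzyl, 4-chlorobenzyl and 4-isopropoxybenzyl groups cannot be told apart in this read-out, even though the change brings in a hydrogen-bond acceptor where the chlorophenyl groups have none. Nothing available here explains why the three numbers lie so close together.

As far as these compounds go, all three compounds keep a substituted benzyl group on the shared core, so it remains open whether an amine or a carboxylic acid on that aromatic ring, or a longer chain in place of the benzyl group, would give a step beyond the scatter. The three compounds also leave open whether any change at this position can shift the number at all, since none of their steps is large enough to be read as a difference.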